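The source may report more compounds than this note shows. Statements on the series, on what has been measured and on what is new or still open speak of the compounds shown alone.

Working notes on the series.

Among the compounds with values here, compound 1 `O=C(O)Cc1sc(Cc2ccccc2)nc1-c1ccc(Cl)cc1` is the smallest of the three measured members. In an in vitro functional assay on HEK285-7 cells for antagonist activity at prostaglandin D2 receptor 2 (Homo sapiens), read by BRET and beta-arrestin recruitment (on this read-out lower numbers stand for smaller maximal responses and higher numbers for larger maximal responses), compound 1 gives 50%, the lowest of the three numbers. Compound 2 `O=C(O)Cc1sc(C(c2ccccc2)c2ccc(F)cc2)nc1-c1ccc(Cl)cc1` gives 80% and compound 3 `COc1ccc(C(c2ccccc2)c2nc(-c3ccc(Cl)cc3)c(CC(=O)O)s2)cc1` gives 80%. Both measured steps from compound 1 add an aryl group to the same saturated chain carbon: a number 30 percentage points higher from compound 1 to compound 2 (beyond the scatter) and a number 30 percentage points higher from compound 1 to compound 3 (beyond the scatter). Between the two larger compounds, no change at the digits printed from compound 2 to compound 3 (within the scatter).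

Compound 4 `Cc1nc(-c2ccc(Cl)cc2)c(CC(=O)O)s1` is not yet measured. It differs from compound 1 by hydrogen in place of phenyl on a saturated chain carbon bound to an aromatic carbon, that is, benzyl to methyl. Within the data shown here, the steps that bear on it are the two from compound 1, which added a ring at a saturated chain carbon and each raised the maximal response beyond the scatter. Among the measured compounds shown here, compound 4 goes the other way, removing a ring from that part of the molecule; no measured pair shows the loss of the phenyl itself. The expectation is therefore a drop, of uncertain size: a number 15 percentage points lower from compound 1 to compound 4 (beyond the scatter). Compound 4 is estimated at 35%, with a range from 15% to 60%.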

Compound 4, largest response reached (reported as efficacy), in percent of the reference or control that the assay uses: 50%
Estimate against measurement, compound 4: 15 percentage points below; the measured number falls inside the stated range.
By their numbers in this assay, from the lowest: compounds 1 and 4 (each within the scatter of the next); then compounds 2 and 3 (each within the scatter of the next).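

For hydrogen in place of phenyl on a saturated chain carbon bound to an aromatic carbon, this assay shows no change at the digits printed from compound 1 to compound 4 (within the scatter), so the single phenyl at this place carries no measurable part of the maximal response. The changes that moved the number were of another kind: an added aryl group on the saturated chain carbon of compound 1 gives a number 30 percentage points higher from compound 1 to compound 2 (beyond the scatter) and a number 30 percentage points higher from compound 1 to compound 3 (beyond the scatter), so at this place only the added aryl groups are seen to shift the read-out. No measurement at hand accounts for this contrast.

Open, from the compounds shown here alone, is whether an amine or a longer chain such as propyl at this place would leave the maximal response unchanged or shift it. Also open, going by these compounds, is whether a single 4-fluorophenyl or 4-methoxyphenyl group, without the second ring, would shift it.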